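The compounds below may be only part of what the source reports. "The series", "measured", "known", "first", "only" and "open" are said of these compounds alone.

Measured in a toxicity assay on NIH3T3 cells (Mus musculus) for cytotoxicity, read by resazurin assay; on this read-out higher numbers stand for an effect only at larger amounts of compound and lower numbers for an effect already at smaller amounts:
- compound 1 `O=C(c1ccc(NCc2cncn2Cc2ccc(-c3ccccc3)cc2)cc1-c1ccccc1)N1CCCCC1`: > 1000 nM
- compound 2 `c1ccc(-c2ccc(Cn3cncc3CNc3ccc(N4CCCCC4)c(-c4ccccc4)c3)cc2)cc1`: > 1000 nM

Compound 2 stands only at a limit, > 1000 nM. Compound 1 is likewise a limit, > 1000 nM. Among the measured compounds shown here, the series so far is the limit of > 1000 nM in this assay, at which 2 of the 2 values shown sit.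

Compound 3 `c1ccc(-c2ccc(Cn3cncc3CNc3ccc(-c4ccc[nH]4)c(-c4ccccc4)c3)cc2)cc1` carries 1H-pyrrol-2-yl in place of piperidin-1-yl on an aromatic carbon.

For the measured compounds named here, the only measured step bearing on this is a step that the two limits leave unreadable from compound 1 to compound 2, which gives no size to carry over. No step beyond the scatter is therefore expected in this assay, and no direction can be assigned, so the expected step is a step that the limit leaves unreadable from compound 2 to compound 3. The estimate for compound 3 is 2000 nM, with an expected range of 700 nM to 8000 nM.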

Compound 3, half-maximal effective concentration: > 10000 nM
Compound 3 gave a limit, no number (the forecaster's own chance of this, stated with the estimate: 65%); at least 5.0-fold (0.69 log units) between middle value and limit.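

Among the compounds shown here, compound 1, compound 2 and compound 3 all stand at limits in this assay, and no step among them can be read. The compounds shown leave open at what concentration any of them takes effect, and what 1H-pyrrol-2-yl in place of piperidin-1-yl does to that concentration.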